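Replacing the Chlorophenyl of Compound 1 with a Hydroxyphenyl

The compounds below may be only part of what the source reports. "The series", "measured", "known", "first", "only" and "open" are said of these compounds alone.

Among the compounds with values here, compound 1 `O=C1CSC(c2ccccc2Cl)N1CCN1CCCCC1` was tested in an ADME assay on Vero cells (Chlorocebus sabaeus) for cytotoxicity, read by neutral red uptake, tested at 394 ug/mL (a lower number here means a stronger effect, a higher number a weaker effect of the compound at the concentration tested), and gives 31%, the lowest of the three numbers known. Compound 2 `O=C1CSC(c2c(Cl)cccc2Cl)N1CCN1CCCCC1` gives 32% in this assay, a step of a number 1 percentage points higher from compound 1 to compound 2 (within the scatter). Compound 3 `O=C1CSC(c2ccccc2[N+](=O)[O-])N1CCN1CCCCC1` gives 100% in this assay, a step of a number 69 percentage points higher from compound 1 to compound 3 (beyond the scatter). Compound 4 `O=C1CSC(c2ccc(O)cc2)N1CCN1CCCCC1` differs from compound 1 by 4-hydroxyphenyl in place of 2-chlorophenyl on a saturated ring carbon. Both measured steps bear on this change: adding a chloro moved nothing, whereas exchanging the chloro for a nitro raised the number far beyond the scatter. The change in compound 4 also removes the chloro, so the number in this assay is expected to rise, by an estimated a number 34 percentage points higher from compound 1 to compound 4 (beyond the scatter). Compound 4 is therefore expected to give 65% in this assay, within 35% to 100%.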

Compound 4, a percentage reported as activity, at one concentration (the size of the read-out at that concentration, not a potency): 76%
The estimate for compound 4 lay 11 percentage points below the measured number, and the stated range covers the measured number.
By their numbers in this assay, from the lowest: compounds 1 and 2 (each within the scatter of the next); then compound 4; then compound 3.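

In this assay, 4-hydroxyphenyl in place of 2-chlorophenyl gives a number 45 percentage points higher from compound 1 to compound 4 (beyond the scatter), so a large rise at this saturated ring carbon does not depend on a nitro group. The change alters both the substituent and its place on the phenyl ring, so this one step cannot separate the loss of the chloro from the arrival of the hydroxy. No measurement at hand gives a reason for the rise. From the compounds shown here alone, it remains open what 2-hydroxyphenyl, plain phenyl, 4-methoxyphenyl or 4-aminophenyl would give at this carbon.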